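Phenyl in place of 1,3-thiazol-2-yl

This account rests on a few compounds, and the source may have more. Where it says the series, first, only, none or still open, it means among the compounds named here.

Of the compounds shown here, two that share a core have been measured in a functional assay on NCI-H460 cells (Homo sapiens) for cytotoxicity, read by MTT assay, with a stated time of 68 h; on this read-out higher numbers stand for weaker inhibition and lower numbers for stronger inhibition. Here compound 1 (`O=C(Nc1cccc(-c2cccc(C(F)(F)F)c2)c1)C(Cl)Cl`) gives 30200 nM as a numeric reading. Compound 2 (`O=C(Nc1cccc(-c2nccs2)c1)C(Cl)Cl`) gives > 50000 nM as a limit of the assay and not a number, so it stands at the limit of > 50000 nM in this assay, at which 1 of the 2 values shown sits.

Compound 3 (`O=C(Nc1cccc(-c2ccccc2)c1)C(Cl)Cl`) follows from compound 2 by one exchange: phenyl in place of 1,3-thiazol-2-yl on an aromatic carbon, with phenyl in place of 1,3-thiazol-2-yl on an aromatic carbon. Among the measured compounds shown here, no measured step covers this exchange. For the measured compounds named here, the expectation therefore leans on compound 1 and its reading of 30200 nM as the only number available. A small move toward stronger inhibition in this assay is expected, estimated as an at least 1.3-fold lower number from compound 2 to compound 3 (0.11 log units; that floor lies within the scatter). Compound 3 is estimated at 38000 nM, with an expected range from 17000 nM to 75000 nM.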

Compound 3, half-maximal inhibitory concentration: 20200 nM
For compound 3 the middle estimate is 1.9-fold (0.27 log units) above the measured one; the range from low to high includes it.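

In this assay, among the compounds shown here, phenyl in place of 1,3-thiazol-2-yl on this aromatic carbon gives an at least 2.4-fold lower number from compound 2 to compound 3 (0.39 log units; beyond the scatter), which gives this exchange a measured direction for the first time. The reading for compound 2 is a limit of the assay and not a number, so this step marks only the smallest change consistent with the data: the limit of > 50000 nM in this assay, at which 1 of the 3 values shown sits. Hydrogen in place of trifluoromethyl on an aromatic carbon gives a 1.5-fold lower number from compound 1 to compound 3 (0.17 log units; within the scatter), so this exchange does not separate compound 1 from compound 3 in this assay.

The compounds shown leave open how an amine or a carboxylic acid in place of trifluoromethyl on the phenyl would read in this assay. They also leave open whether a pyridyl ring at this position would read closer to phenyl or to 1,3-thiazol-2-yl.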